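Methyl in Place of Bromo on the Aromatic Ring

The source may hold more compounds than are shown below. What is called first, only, known or untested is meant among the compounds shown, and "the series" means these compounds.

Compound 1 `O=C(CCC1=CCN(CCCc2ccc(Br)cc2)C1=O)NO`: 2520 nM
Compound 2 `O=C(CCC1=CCN(Cc2ccc(F)cc2)C1=O)NO`: 4670 nM
Compound 3 `CC(C)(C)c1ccc(CN2CC=C(CCC(=O)NO)C2=O)cc1`: 420 nM

All three were tested in a functional assay on NCI-H23 cells (Homo sapiens) for inhibition, read by sulforhodamine B assay; a lower number here means a stronger inhibitor of growth, a higher number a weaker inhibitor of growth. Compound 1 stands second highest of the three numbers: compound 2 sits within the scatter of it, while compound 3 lies beyond the scatter below it. Compound 4 `Cc1ccc(CCCN2CC=C(CCC(=O)NO)C2=O)cc1` differs from compound 1 by methyl in place of bromo on an aromatic carbon. For the measured compounds named here, the one measured step at the same kind of position, an 11-fold lower number from compound 2 to compound 3 (1.05 log units; beyond the scatter), was large, but there a single heavy atom gave way to a five-atom group; here one heavy atom leaves and one enters. No movement beyond the scatter is therefore expected in this assay. The estimate for compound 4 is 2000 nM, ranging from 800 nM to 5000 nM. That estimate means an expected 1.3-fold lower number from compound 1 to compound 4 (0.10 log units; within the scatter).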

Compound 4, concentration for 50% growth inhibition: 2520 nM
Estimate against measurement, compound 4: 1.3-fold (0.10 log units) below; the range from low to high includes it.
By their numbers in this assay, from the lowest: compound 3; then compounds 1, 4 and 2 (each within the scatter of the next).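

In this assay, replacing bromo with methyl on the aromatic carbon para to a large group gave no change at the digits printed from compound 1 to compound 4 (within the scatter). The 4-bromophenyl and 4-methylphenyl compounds thus read alike, a swap of one heavy atom for another that contrasts with the large step seen for fluoro and tert-butyl, an 11-fold lower number from compound 2 to compound 3 (1.05 log units; beyond the scatter). No available evidence explains this equivalence. The compounds shown leave open whether an amine or a carboxylic acid at this place on compound 1 would leave the number within the scatter or move it beyond.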